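The source may report more compounds than this note shows. Statements on the series, on what has been measured and on what is new or still open speak of the compounds shown alone.

Three compounds sharing one core were examined in a functional assay on the whole organism (Pleural cavity) with Rattus norvegicus as the target; a higher number here means that more compound is needed for the effect, a lower number that less compound is needed. Compound 1 `OC[C@H]1O[C@@H](n2cnc3c(NCc4ccccc4)nccc32)C[C@@H]1O` returns only a limit of the assay, > 9 mg/kg. Compound 2 `c1ccc(CNc2[nH]ccc3ncnc2-3)cc1` gives 9 mg/kg. Compound 3 `CCCCCCNc1[nH]ccc2ncnc1-2` likewise returns only a limit, > 9 mg/kg. Going by the values given here, compound 3 therefore stands at the limit of > 9 mg/kg in this assay, at which 2 of the 3 values shown sit, and no pair of measured compounds differing in a single place is available to guide a prediction. Compound 4 `OCCNc1[nH]ccc2ncnc1-2` differs from compound 3 by hydroxy in place of butyl on a saturated chain carbon, two bonds along the chain from a nitrogen on an aromatic ring. Among the compounds with values here, with no measured step to lean on, the step from compound 3 to compound 4 is expected to be small, a step that the limit leaves unreadable from compound 3 to compound 4, with no direction established beyond the scatter. Compound 4 is expected to come out near 12 mg/kg, within a range of 5 mg/kg to 30 mg/kg, quite possibly again as a limit.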

Compound 4, dose for half-maximal effect: > 9 mg/kg
Compound 4 ended at the assay's limit; the forecaster's own chance of this, stated with the estimate: 60%; the middle value lies beyond the limit too.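

Compound 3 and compound 4 both return only a limit of the assay, so no step between them can be read: the limit of > 9 mg/kg in this assay, at which 3 of the 4 values shown sit.

Going by these compounds, whether hydroxy in place of butyl alters the dose needed in this assay remains open.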